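The source may hold more compounds than are shown below. What is called first, only, known or untested is meant among the compounds shown, and "the series" means these compounds.

Measured in a functional assay on A2780 cells (Homo sapiens) for antiproliferative activity, read by fluorescence, with a stated time of 72 h; on this read-out lower numbers stand for stronger inhibition and higher numbers for weaker inhibition:
- compound 1 `CC(=O)N1CCN(C(=O)N2Cc3c(NC(=O)c4ccc(F)cc4)n[nH]c3C2(C)C)CC1`: > 10000 nM, a limit of the assay
- compound 2 `CN1CCC(C(=O)N2Cc3c(NC(=O)C4CC4)n[nH]c3C2(C)C)CC1`: 1420 nM

Within the data shown here, compound 2 holds the only actual number so far, as the entry for compound 1 is the limit of > 10000 nM in this assay, at which 1 of the 2 values shown sits. Compound 3 `CN1CCC(C(=O)N2Cc3c(NC(=O)C4CCC4)n[nH]c3C2(C)C)CC1` differs from compound 2 in one place: cyclobutyl in place of cyclopropyl on a carbonyl carbon, (cyclobutyl in place of cyclopropyl on a carbonyl carbon). Among the measured compounds shown here, no measured step covers this change, so the expectation rests on compound 2 at 1420 nM, with no shift beyond the scatter expected in this assay. The expected change is a 1.1-fold lower number from compound 2 to compound 3 (0.04 log units; within the scatter). The estimate for compound 3 is 1300 nM, with an expected range of 450 nM to 4000 nM.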

Compound 3, half-maximal inhibitory concentration: 140 nM
Beside the measured number, compound 3's estimate is 9.3-fold (0.97 log units) above it; measured number below the stated range.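

In this assay, among these compounds, cyclobutyl in place of cyclopropyl on a carbonyl carbon gives a 10-fold lower number from compound 2 to compound 3 (1.01 log units; beyond the scatter) and is the first step that can be read. The number at this position thus shifts beyond the scatter on the exchange of one carbon ring for another, with hydrogen-bond donors, hydrogen-bond acceptors and net charge unchanged. No measurement shown gives a cause for this step.

On these data alone, whether a cyclopentyl ring or an open isopropyl chain on this carbonyl carbon would extend the step remains open. Also open, as far as these compounds go, is whether the same exchange has a similar effect when the other acyl group on the core is changed.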